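A few compounds are considered here, and "the series" means these few. Any claim that something is new, unique, unknown or untested is made for them only; others in the source may bear on it.

Measured compounds:
- compound 1 `CCC(C)N(C(C)CC)S(=O)(=O)c1ccc(NC(=O)C(C)(O)C(F)(F)F)cc1`: > 30000 nM
- compound 2 `CC(O)(C(=O)Nc1ccc(S(N)(=O)=O)cc1)C(F)(F)F`: 12800 nM
- compound 3 `CC(O)(C(=O)Nc1ccc([C@H](O)c2ccccc2)cc1)C(F)(F)F`: > 30000 nM

All three share a core carrying a trifluoromethyl-bearing hydroxy amide, and differ only in the group on the far side of the aromatic ring. In an assay on a protein complex (Cavia porcellus) with sulfonylurea receptors; K-ATP channels (Homo sapiens) as the target (a higher number here means a weaker inhibitor, a lower number a stronger inhibitor), compound 2 gives 12800 nM. For compound 3 the result is only a limit, > 30000 nM, so its true number is not known. Compound 1 likewise sits at a limit, > 30000 nM (the limit of > 30000 nM in this assay, at which 2 of the 3 values shown sit). Two steps frame the series: an at least 2.3-fold lower number from compound 1 to compound 2 (0.36 log units; beyond the scatter), and an at least 2.3-fold higher number from compound 2 to compound 3 (0.36 log units; beyond the scatter). Compound 4 `CC(O)(C(=O)Nc1ccc(S(=O)(=O)N2CCCC2)cc1)C(F)(F)F` is not yet measured; it differs from compound 3 by (pyrrolidin-1-yl)sulfonyl in place of hydroxy(phenyl)methyl on an aromatic carbon. This returns a sulfonyl group, as in compound 2, but with the nitrogen carrying a ring rather than two hydrogens, which resembles compound 1 more than compound 2. A modest change in this assay is therefore expected, probably toward a lower number than the limit of compound 3 but with a real chance of another limit; the expected step is an at least 1.2-fold lower number from compound 3 to compound 4 (0.07 log units; that floor lies within the scatter). Compound 4 is estimated at 25000 nM, within 8000 nM to 60000 nM.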

Compound 4, half-maximal inhibitory concentration: 880 nM
For compound 4 the middle estimate is 28-fold (1.45 log units) above the measured one; measured number outside the range, below it.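

In this assay, keeping the sulfonyl group and changing only what sits on its sulfur gives a 15-fold lower number from compound 2 to compound 4 (1.16 log units; beyond the scatter), so at this position the sulfonyl group alone does not set the result. Size of the nitrogen group alone does not explain it either, as a substituted nitrogen appears in both directions: an at least 34-fold lower number from compound 1 to compound 4 (1.53 log units; beyond the scatter), and replacing the hydroxy(phenyl)methyl group gives an at least 34-fold lower number from compound 3 to compound 4 (1.53 log units; beyond the scatter). These last two steps are only floors, as compound 1 and compound 3 each stand at a limit: the limit of > 30000 nM in this assay, at which 2 of the 4 values shown sit.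

What the compounds shown cannot say is why the pyrrolidin-1-yl ring does so much better than amino or bis(sec-butyl)amino. A piperidine ring, a morpholine ring or a dimethylamino group on the same sulfur would show whether the ring, its size or simply a small pair of carbon groups is what counts.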